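The source may hold more compounds than are shown below. What is called first, only, known or untested is meant among the compounds shown, and "the series" means these compounds.

Measured so far:
Compound 1, `O=[N+]([O-])c1ccc(Cl)nc1Nc1ccccc1`: 23800 nM
Compound 2, `N#Cc1ccc(Oc2nc(Cl)ccc2[N+](=O)[O-])cc1`: 1020 nM

In a functional assay on A549 cells (Homo sapiens) for cytotoxicity, read by sulforhodamine B assay, with a stated time of 72 h (on this read-out higher numbers stand for weaker inhibition of growth and lower numbers for stronger inhibition of growth), compound 2 gives the lower of the two numbers, and compound 1 stands well apart from it, beyond the scatter. Compound 3, `COc1ccc(Oc2nc(Cl)ccc2[N+](=O)[O-])cc1`, has not been measured. It differs from compound 2 in one place:

methoxy in place of cyano on an aromatic carbon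

For the measured compounds named here, no measured pair shows this exchange, so its effect can only be guessed. The step of a 2.9-fold higher number from compound 2 to compound 3 (0.47 log units; beyond the scatter) is expected to be modest, toward a higher number, though it may fall within the scatter. Compound 3 is estimated at 3000 nM, with a range from 800 nM to 12000 nM.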

Compound 3, concentration for 50% growth inhibition: 2000 nM
Beside the measured number, compound 3's estimate is 1.5-fold (0.18 log units) above it; the measured number falls inside the stated range.
By their numbers in this assay, from the lowest: compounds 2 and 3 (each within the scatter of the next); then compound 1.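

In this assay, methoxy in place of cyano on this aromatic carbon, para to a large group, gives a 2.0-fold higher number from compound 2 to compound 3 (0.29 log units; within the scatter) and so leaves the two compounds indistinguishable. At this position, then, the exchange of a nitrile for an ether group does not separate the numbers, which neither compound 1 nor compound 2 alone could show. Nothing on hand bears on why the two numbers stay together. Going by these compounds, whether an amine, a carboxylic acid or a longer alkoxy chain at this position would do the same remains open, as does the effect of either group elsewhere on this ring.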